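A few compounds are considered here, and "the series" means these few. Any claim that something is new, unique, unknown or untested is made for them only; others in the source may bear on it.

Compound 1 `COC(=O)C12CC1CCN(C(=O)[C@H](CC(C)C)NC(=O)[C@H](CO)NC(=O)[C@@H](NC(=O)c1cccc(O)c1C)C(C)C)C2`, compound 2 `COC(=O)C12CC1CCN(C(=O)[C@H](CC(C)C)NC(=O)[C@H](CO)NC(=O)[C@@H](NC(=O)C1=CCCNC1)C(C)C)C2` and compound 3 `COC(=O)C12CC1CCN(C(=O)[C@H](CC(C)C)NC(=O)[C@H](CC(C)C)NC(=O)[C@H](CC(C)C)NC(=O)c1cccc(O)c1C)C2` have been measured in an ADME assay on a cell-free system (plasma, Homo sapiens) for metabolic stability; a higher number here means that the compound lasts longer, a lower number that the compound disappears faster. In this assay compound 1 reaches a limit of the assay rather than a number, > 6 h. Compound 2 gives 4.92 h. Compound 3 also sits at a limit of the assay, > 6 h. The core of compound 3 differs from the core of compound 1 in more than one place, and that difference is not broken down here.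

From compound 1 to compound 2 the change is a group of 6 heavy atoms (5 carbon, 1 nitrogen; one six-membered non-aromatic ring with 1 hetero atom) in place of a group of 8 heavy atoms (7 carbon, 1 oxygen; one six-membered aromatic ring of carbon only), on a carbonyl carbon. It made an at least 1.2-fold lower number from compound 1 to compound 2 (0.08 log units; that floor lies within the scatter). Because the limit of > 6 h in this assay, at which 2 of the 3 values shown sit, applies to compound 1, only a floor can be stated for that step, and the true drop may be larger.

Compound 4 `COC(=O)C12CC1CCN(C(=O)[C@H](CC(C)C)NC(=O)[C@H](CC(C)C)NC(=O)[C@H](CC(C)C)NC(=O)C1=CCCNC1)C2` has not yet been measured. From compound 3 to compound 4 the same change is made, at the same place: a group of 6 heavy atoms (5 carbon, 1 nitrogen; one six-membered non-aromatic ring with 1 hetero atom) in place of a group of 8 heavy atoms (7 carbon, 1 oxygen; one six-membered aromatic ring of carbon only), on a carbonyl carbon. As compound 3 is also at a limit, the starting point is uncertain in the same way. The step is expected to be an at least 1.2-fold lower number from compound 3 to compound 4 (0.07 log units; that floor lies within the scatter), resting on an at least 1.2-fold lower number from compound 1 to compound 2 (0.08 log units; that floor lies within the scatter). Compound 4 is expected to give 5 h, most likely between 3 h and 8 h.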

Compound 4, half-life: > 6 h
Compound 4: a limit, no number; the forecaster's own chance of this, stated with the estimate: 35%; at least 1.2-fold (0.07 log units) between middle value and limit.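

No step can be read from compound 3 to compound 4, as both compounds stop at the same limit in this assay: the limit of > 6 h in this assay, at which 3 of the 4 values shown sit.

From the compounds shown here alone, what stays open is how long compound 3 and compound 4 really last, and so whether replacing the 3-hydroxy-2-methylphenyl group with the six-membered non-aromatic ring shortens the half-life in compound 4 at all.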